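Aryl Ring in Place of Sulfonyl on the Ring Amine Nitrogen

The compounds below may be only part of what the source reports. "The series", "measured", "known", "first", "only" and "open" are said of these compounds alone.

Compound 1 `CCCS(=O)(=O)N1CC=C(c2ccc3c(c2)CC(C2CCN(Cc4ccccc4)CC2)O3)CC1` gives 521 nM in a functional assay on HEK293 cells for agonist activity at Glucose-dependent insulinotropic receptor (Homo sapiens), read by cAMP accumulation, with a stated time of 60 min; a lower number here means that less compound is needed, a higher number that more compound is needed for the effect.
Compound 2 `CCCS(=O)(=O)N1CC=C(c2ccc3c(c2)CC(C2CCN(S(=O)(=O)CCC)CC2)O3)CC1` gives 1000 nM in this assay.
Compound 3 `CCCS(=O)(=O)N1CC=C(c2ccc3c(c2)CC(C2CCN(c4ncc(Cl)cn4)CC2)O3)CC1` gives 78 nM in this assay.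

Compound 2 shows the highest number of the three, though its gap to compound 1, a 1.9-fold higher number from compound 1 to compound 2 (0.28 log units; within the scatter), lies within the scatter. The step of a 13-fold lower number from compound 2 to compound 3 (1.11 log units; beyond the scatter) is large and beyond the scatter.

Compound 4 `CCCS(=O)(=O)N1CC=C(c2ccc3c(c2)CC(C2CCN(c4ccc(C(F)(F)F)cn4)CC2)O3)CC1` has not been measured. It differs from compound 2 by 5-(trifluoromethyl)pyridin-2-yl in place of propylsulfonyl on an amine nitrogen in a ring. This resembles the change to compound 3, where an aromatic ring also replaced the propylsulfonyl and gave a 13-fold lower number from compound 2 to compound 3 (1.11 log units; beyond the scatter). A step of similar size and direction is expected here, a 9.1-fold lower number from compound 2 to compound 4 (0.96 log units; beyond the scatter). Compound 4 is therefore estimated at 110 nM, within 40 nM to 300 nM.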

Compound 4, half-maximal effective concentration: 34 nM
For compound 4 the middle estimate is 3.2-fold (0.51 log units) above the measured one, and the stated range ends above it.
By their numbers in this assay, from the lowest: compound 4; then compound 3; then compounds 1 and 2 (each within the scatter of the next).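

In this assay, an aromatic ring on the amine nitrogen again lowers the number, with a 29-fold lower number from compound 2 to compound 4 (1.47 log units; beyond the scatter) and a 15-fold lower number from compound 1 to compound 4 (1.19 log units; beyond the scatter). The two aromatic groups are also not interchangeable, as 5-(trifluoromethyl)pyridin-2-yl in place of 5-chloropyrimidin-2-yl gives a 2.3-fold lower number from compound 3 to compound 4 (0.36 log units; beyond the scatter). Nothing available explains these steps. As far as these compounds go, compound 3 and compound 4 differ in both ring and substituent, so the contribution of each remains open. A pyridin-2-yl ring without trifluoromethyl and a phenyl ring carrying trifluoromethyl would help separate them.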